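Fluoro for hydrogen on the phenyl ring of compound 1

The source may hold more compounds than are shown below. What is called first, only, known or untested is meant among the compounds shown, and "the series" means these compounds.

Compounds measured so far:
compound 1, `COc1cc(NC(=O)N2C=CC(=O)C[C@H]2c2ccccc2)c(Br)cc1Cl`: 33 nM
compound 2, `COc1cc(NC(=O)N2C=CC(=O)C[C@@H]2c2ccccc2)c(Br)cc1Cl`: > 10000 nM (a limit of the assay)

For the measured compounds named here, in an assay on 1321-N1 cells for antagonist activity at P2X purinoceptor 7 (Homo sapiens), read by FLIPR, with stated times of 20 min, 1 s and 60 s, in the presence of a further agent that is not named here (a higher number here means a weaker inhibitor, a lower number a stronger inhibitor), compound 1 gives 33 nM, the only number among the two values shown. Compound 2 has the same atoms and bonds and differs only in the configuration as drawn. In this assay compound 2 gives only a limit, > 10000 nM. The step of an at least 300-fold higher number from compound 1 to compound 2 (2.48 log units; beyond the scatter) rests on the limit of > 10000 nM in this assay, at which 1 of the 2 values shown sits, and on (the fact that compounds 1 and 2 differ only in the configuration as drawn).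

Compound 3, `COc1cc(NC(=O)N2C=CC(=O)C[C@H]2c2ccc(F)cc2)c(Br)cc1Cl`, keeps the configuration of compound 1 and differs from it in one place: fluoro in place of hydrogen on an aromatic carbon. Going by the values given here, the single measured step concerns configuration alone and does not bear on this change, so no step beyond the scatter is expected, a 1.1-fold lower number from compound 1 to compound 3 (0.04 log units; within the scatter). For compound 3 in this assay the expected value is 30 nM, with a range from 10 nM to 100 nM.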

Compound 3, half-maximal inhibitory concentration: 37 nM
The estimate for compound 3 lay 1.2-fold (0.09 log units) below the measured number; low and high end bracket the measured number.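

In this assay, the step is a 1.1-fold higher number from compound 1 to compound 3 (0.05 log units; within the scatter), so the numbers for the phenyl and 4-fluorophenyl compounds cannot be told apart. For the compounds shown here, the earlier pair spoke only to configuration, whereas this result is the first reading of a change on the phenyl ring itself, made with the configuration of compound 1 kept, and it shows that fluoro can stand in place of hydrogen at this aromatic carbon without a step beyond the scatter. Nothing given here bears on why this is so.

As far as these compounds go, whether this position would accept a group other than fluoro, such as a methoxy group, an amine or a carboxylic acid, remains open. So does the effect of fluoro on other carbons of the same ring.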